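The source may report more compounds than this note shows. Statements on the series, on what has been measured and on what is new or still open speak of the compounds shown alone.

Measured so far:
compound 1 `Cc1nn(-c2ncnc3nc[nH]c23)c2c1C(OCc1cc(F)cc3c1OCOC3)CC(=O)N2` gives 30 nM in a functional assay on HEK293 cells for agonist activity at G-protein coupled receptor 39 (Homo sapiens), read by scintillation proximity assay and inositol phosphate accumulation, with a stated time of 75 min; a lower number here means that less compound is needed, a higher number that more compound is needed for the effect
compound 2 `Cc1nn(-c2ncnc3nc[nH]c23)c2c1C(OCCn1cccn1)CC(=O)N2` gives 2270 nM in this assay

Compound 1 stands lowest of the two numbers in this assay; its nearest neighbour is compound 2, reached by a 76-fold higher number from compound 1 to compound 2 (1.88 log units; beyond the scatter). Compound 3 `Cc1nn(-c2ncnc3nc[nH]c23)c2c1C(OCC(C)C)CC(=O)N2` differs from compound 1 as follows: a group of 3 heavy atoms (3 carbon; no ring) in place of a group of 11 heavy atoms (8 carbon, 2 oxygen, 1 fluorine; one six-membered non-aromatic ring with 2 hetero atoms, one six-membered aromatic ring of carbon only), on a saturated chain carbon bound to an oxygen on a saturated carbon. Thus the isopropyl enters where compound 1 carries the group of 11 heavy atoms with its two rings. For the measured compounds named here, the only measured step that bears on this place is the one from compound 1 to compound 2, where a smaller ring-bearing group replaced the same 11-atom group and the number in this assay rose by a large amount. Isopropyl is smaller still and has no ring, so a step of similar or greater size in the same direction is expected, a 120-fold higher number from compound 1 to compound 3 (2.07 log units; beyond the scatter). For compound 3 the estimate in this assay is 3500 nM, with a range from 800 nM to 15000 nM.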

Compound 3, half-maximal effective concentration: 111 nM
Compound 3: middle estimate off by 32-fold (1.50 log units), on the high side, and the stated range ends above it.
By their numbers in this assay, from the lowest: compound 1; then compound 3; then compound 2.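

In this assay, replacing the two-ring group of compound 1 with isopropyl gives a 3.7-fold higher number from compound 1 to compound 3 (0.57 log units; beyond the scatter) and so costs much less than the pyrazole-bearing group of compound 2 suggested, while the direct comparison gives a 20-fold lower number from compound 2 to compound 3 (1.31 log units; beyond the scatter) on the same saturated chain carbon. The number therefore does not follow group size across these compounds: compound 3 carries the smallest group yet lies between compound 1 and compound 2, and compound 2 goes against any simple size trend. Nothing at hand accounts for the high number of compound 2.

Still open, going by these compounds, is whether a plain benzyl group, keeping an aromatic ring without the fluorine or the oxygen-bearing ring, would close the remaining step to compound 1. On these data alone, the effect of a longer alkyl chain, or of an amine or a carboxylic acid at the chain end, also remains open.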